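A few compounds are considered here, and "the series" means these few. Any claim that something is new, unique, unknown or untested is made for them only; others in the source may bear on it.

Working notes on the series. In a functional assay, with a stated time of 20 min (a lower number here means a stronger inhibitor, a higher number a weaker inhibitor), compound 1 `COc1ccc(-c2nc(NN)n(C)c(=O)c2C#N)cc1` gives 41 ug/mL and compound 2 `CCOC(=O)c1cnn(-c2nc(-c3ccccc3F)c(C#N)c(=O)n2C)c1N` gives 69 ug/mL. Among the measured compounds shown here, the two values lie within the scatter of each other, so compound 2 stands level with compound 1 on the numbers so far. Compound 3 `CCOC(=O)c1cnn(-c2nc(-c3cccc(O)c3O)c(C#N)c(=O)n2C)c1N` carries 2,3-dihydroxyphenyl in place of 2-fluorophenyl on an aromatic carbon. For the measured compounds named here, no measured pair isolates a single change, so the data offer no direct guide. A moderate move to a lower number in this assay is expected, beyond the scatter, though with wide uncertainty. The expected change is a 3.1-fold lower number from compound 2 to compound 3 (0.50 log units; beyond the scatter). For compound 3 the estimated value is 22 ug/mL, with an expected range of 7 ug/mL to 70 ug/mL.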

Compound 3, half-maximal inhibitory concentration: 41 ug/mL
Compound 3: middle estimate off by 1.9-fold (0.27 log units), on the low side; the range from low to high includes it.
By their numbers in this assay, from the lowest: compounds 1, 3 and 2 (each within the scatter of the next).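

In this assay, 2,3-dihydroxyphenyl in place of 2-fluorophenyl on an aromatic carbon ortho to a cyano group gives a 1.7-fold lower number from compound 2 to compound 3 (0.23 log units; within the scatter). Among the compounds shown here, this is the first single-place comparison, and it shows that these two groups cannot be told apart at this position, despite the hydrogen-bond donors and acceptors that enter with 2,3-dihydroxyphenyl. Nothing on hand bears on why the two groups read alike. Still open, as far as these compounds go, is whether a phenyl ring carrying an amine or a carboxylic acid would read beyond the scatter at this position.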